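The source may report more compounds than this note shows. Statements on the series, on what has been measured and on what is new or still open speak of the compounds shown alone.

Measured in a functional assay on MCF7 cells (Homo sapiens) for cytotoxicity, read by MTT assay, with a stated time of 72 h; on this read-out lower numbers stand for stronger inhibition and higher numbers for weaker inhibition:
- compound 1 `CNC(=O)c1cc(Oc2ccc(NC(=O)c3cc(-c4ccc(Cl)cc4)ncn3)cc2F)ccn1`: > 100000 nM
- compound 2 `CNC(=O)c1cc(Oc2ccc(NC(=O)c3cc(-c4ccc(C)cc4)ncn3)cc2)ccn1`: 34600 nM

The entry for compound 1 is a limit of the assay, not a number. Among the compounds with values here, compound 2, at 34600 nM, holds the only numerical value so far. Compound 3 `CCc1ccc(-c2cc(C(=O)Nc3ccc(Oc4ccnc(C(=O)NC)c4)cc3)ncn2)cc1` follows from compound 2 by methyl in place of hydrogen on a saturated chain carbon bound to an aromatic carbon, with methyl in place of hydrogen on a saturated chain carbon bound to an aromatic carbon, so 4-methylphenyl becomes 4-ethylphenyl. Within the data shown here, no measured step covers this change. A shift beyond the scatter is not expected in this assay, and the expected step is a 1.2-fold higher number from compound 2 to compound 3 (0.06 log units; within the scatter). Compound 3 is estimated at 40000 nM, with an expected range of 15000 nM to 100000 nM.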

Compound 3, half-maximal inhibitory concentration: 6350 nM
The estimate for compound 3 lay 6.3-fold (0.80 log units) above the measured number, outside the stated range (below it).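

In this assay, within the data shown here, the change from 4-methylphenyl to 4-ethylphenyl gives a 5.4-fold lower number from compound 2 to compound 3 (0.74 log units; beyond the scatter) as the first readable step. The saturated chain carbon bound to an aromatic carbon therefore responds to a single added methyl, which compound 1 could not show, as it differs from compound 2 in more than one place. No measurement shown here bears on the cause of this step.

A single step sets no trend. As far as these compounds go, whether a propyl chain, a branched isopropyl group or a terminal amine at this position would extend or reverse the step remains open.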